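Dropping the Fluorine: From Compound 2 to Compound 4

The source may report more compounds than this note shows. Statements on the series, on what has been measured and on what is new or still open speak of the compounds shown alone.

Of the compounds shown here, three sharing one core have been measured in a functional assay on MGC-803 cells (Homo sapiens) for antiproliferative activity, read by CCK-8 assay, with a stated time of 72 h, tested at 2 uM; a lower number here means a weaker effect, a higher number a stronger effect of the compound at the concentration tested. Compound 1 `Nc1ccccc1NC(=O)c1ccc(CSC(=S)N2CCN(c3ccc(Cl)cc3)CC2)cc1` gives 15%. Compound 2 `Nc1ccccc1NC(=O)c1ccc(CSC(=S)N2CCN(c3ccc(F)cc3)CC2)cc1` gives 18.8%, and the other two numbers lie within the usual scatter of it. Compound 3 `Nc1ccccc1NC(=O)c1ccc(CSC(=S)N(Cc2ccccc2)Cc2ccccc2)cc1` gives 11%. Going by the values given here, the single step between compounds differing in one place, a number 3.8 percentage points higher from compound 1 to compound 2 (within the scatter), stays within the scatter.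

The change from compound 2 to compound 4 `Nc1ccccc1NC(=O)c1ccc(CSC(=S)N2CCN(c3ccccc3)CC2)cc1` is hydrogen in place of fluoro on an aromatic carbon. Among the compounds with values here, the only measured step that bears on it is a number 3.8 percentage points higher from compound 1 to compound 2 (within the scatter), fluoro in place of chloro on an aromatic carbon of the same ring, and it did not move the read-out beyond the scatter. Within the data shown here, no measured step removes the substituent from that ring entirely, so the expectation rests on that one small step alone: in this assay a step of a number 1.8 percentage points lower from compound 2 to compound 4 (within the scatter) is expected, meaning no movement beyond the scatter. Compound 4 is therefore estimated at 17%, with a range from 9% to 25%.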

Compound 4, a percentage reported as inhibition, at one concentration (the size of the read-out at that concentration, not a potency): 42.3%
The estimate for compound 4 lay 25.3 percentage points below the measured number, outside the stated range (above it).
By their numbers in this assay, from the lowest: compounds 3, 1 and 2 (each within the scatter of the next); then compound 4.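

At the aromatic carbon para to a large group, the choice between a halogen and hydrogen matters far more than the choice between the two halogens. In this assay, replacing either halogen with hydrogen gives a clear rise: a number 23.5 percentage points higher from compound 2 to compound 4 (beyond the scatter), and a number 27.3 percentage points higher from compound 1 to compound 4 (beyond the scatter), whereas fluoro and chloro could not be told apart. Nothing available here explains why the plain phenyl compound stands above both halogen-bearing compounds.

The compounds shown leave open whether this rise is specific to removing a halogen, or whether a different small group at the same carbon, such as methyl, methoxy or an amine, would also keep the read-out high. As this is a read-out at a single concentration, they also leave open how compound 4 compares in potency.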